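The source may report more compounds than this note shows. Statements on the series, on what has been measured and on what is new or still open speak of the compounds shown alone.

Compound 1 `C=CC(=O)N1CC[C@H](N2C(=O)N(C3CCCC3)Cc3cnc(Nc4ccc(N5CCN(C)CC5)cc4OC)nc32)C1`: 250 ug/mL
Compound 2 `C=CC(=O)N1CCC[C@@H](N2C(=O)N(Cc3ccccc3)Cc3cnc(Nc4ccc(N5CCN(C)CC5)cc4OC)nc32)C1`: 142 ug/mL
Compound 3 `C=CC(=O)NC1CCC(N2C(=O)N(Cc3ccccc3)Cc3cnc(Nc4ccc(N5CCN(C)CC5)cc4OC)nc32)CC1`: 18.8 ug/mL

Of the compounds shown here, three have been measured in a physicochemical assay for solubility, read by HPLC, in phosphate buffer, measured as thermodynamic solubility, with a stated time of 24 h, at pH 6.8; a higher number here means a more soluble compound, a lower number a less soluble compound. Compound 1 stands highest of the three numbers; compound 2 lies within the scatter of it, and only compound 3 falls clearly beyond. Among the compounds with values here, the one step between compounds that differ in a single place is a 7.6-fold lower number from compound 2 to compound 3 (0.88 log units; beyond the scatter), which concerns the group on the ring nitrogen that carries the acrylamide-bearing ring and not the group on the amide-type nitrogen.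

Compound 4 `C=CC(=O)N1CC[C@H](N2C(=O)N(C3CCCCC3)Cc3cnc(Nc4ccc(N5CCN(C)CC5)cc4OC)nc32)C1` has not yet been measured. It differs from compound 1 as follows: cyclohexyl in place of cyclopentyl on an amide-type nitrogen in a ring. Within the data shown here, no measured step touches this position, so the measured step from compound 2 to compound 3 does not bear on it directly. With one carbon added to a saturated ring, no step beyond the scatter is expected in this assay. Compound 4 is therefore estimated at 180 ug/mL, within a range from 90 ug/mL to 350 ug/mL. That estimate means an expected step of a 1.4-fold lower number from compound 1 to compound 4 (0.14 log units; within the scatter).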

Compound 4, solubility: 763 ug/mL
Compound 4: the middle estimate sits 4.2-fold (0.63 log units) below what was measured; the measured number lies above the stated range.
By their numbers in this assay, from the lowest: compound 3; then compounds 2 and 1 (each within the scatter of the next); then compound 4.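

In this assay, the amide-type nitrogen in a ring proves to be a place where a small change in a saturated carbon ring can shift the number: cyclohexyl in place of cyclopentyl gives a 3.1-fold higher number from compound 1 to compound 4 (0.48 log units; beyond the scatter). Neither group carries hydrogen-bond donors, hydrogen-bond acceptors or a net charge, so this step comes with a change of ring size and carbon count alone. Within the data shown here, the only step available earlier concerned the group bearing the acrylamide, so this is the first reading at this position. Nothing at hand explains the step.

As far as these compounds go, whether the number keeps rising with cycloheptyl, or holds with an open chain such as isopropyl or a ring bearing an amine, remains open. So does whether the same step appears with a 1-(vinylcarbonyl)piperidin-3-yl group in place of the 1-(vinylcarbonyl)pyrrolidin-3-yl group.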